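Cytotoxicity notes on the shared core: ethylamino analogue

The source may hold more compounds than are shown below. What is called first, only, known or untested is meant among the compounds shown, and "the series" means these compounds.

Compound 1 `CCOc1ccc(-n2nnc3n[nH]c(NC)c3c2=O)cc1`: in an ADME assay on TERT-RPE1 cells (Homo sapiens) for cytotoxicity, read by resazurin assay, with a stated time of 48 h (a lower number here means a stronger inhibitor, a higher number a weaker inhibitor), compound 1 gives > 100000 nM, a limit of the assay.
Compound 2 `C=CCN/C(SC)=C(/C#N)C(=O)Nc1ccc(OCC)cc1`: in this assay compound 2 gives > 100000 nM, again a limit.
Compound 3 `CCOc1ccc(-n2nnc3n[nH]c(Nc4ccccc4)c3c2=O)cc1`: in this assay compound 3 gives > 100000 nM, also a limit.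

Compound 3 stands where every measured value stands, at the limit of > 100000 nM in this assay, at which 3 of the 3 values shown sit. The step that the two limits leave unreadable from compound 1 to compound 3 is left unreadable by the two limits, so no size can be taken from it. Compound 4 `CCNc1[nH]nc2nnn(-c3ccc(OCC)cc3)c(=O)c12` differs from compound 3 by ethyl in place of phenyl on a nitrogen on an aromatic ring. Within the data shown here, no measured step with a readable size bears on this change; the one neighbouring step runs between two limits. The expected step is a step that the limit leaves unreadable from compound 3 to compound 4, nothing beyond the scatter, with a limit the most likely outcome. The estimate for compound 4 in this assay is 150000 nM, within 50000 nM to 500000 nM.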

Compound 4, half-maximal inhibitory concentration: > 100000 nM
Compound 4: a limit, no number; the forecaster's own chance of this, stated with the estimate: 85%; the middle value lies beyond the limit too.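

In this assay compound 4 gives > 100000 nM, a limit of the assay. Among these compounds, no step among compound 1, compound 3 and compound 4 can be read. The compounds shown leave open whether any change on the shared core alters cytotoxicity, with every value at one limit: the limit of > 100000 nM in this assay, at which 4 of the 4 values shown sit.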